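From a Carboxylic Acid to a Methyltetrazole

The source may report more compounds than this note shows. Statements on the series, on what has been measured and on what is new or still open speak of the compounds shown alone.

Compound 3 `CCc1cc(C(C)=O)c(O)cc1OCCCCCC(C)(C)C(=O)O` gives 20% in an assay on isolated protein for binding affinity to leukotriene B4 receptor (Homo sapiens), tested at 0.1 uM (a lower number here means less inhibition, a higher number more inhibition at the concentration tested (going by the name of the read-out)), the largest of the three numbers shown, though no pair of them differs beyond the scatter. Compound 1 `CCc1cc(C(C)=O)c(O)cc1OCCCCCC(C)(C)C#N` gives 17%, and compound 2 `CCc1cc(C(C)=O)c(O)cc1OCCCCCCC(C)(C)C#N` gives 11%; the steps of a number 3 percentage points higher from compound 1 to compound 3 (within the scatter) and a number 9 percentage points higher from compound 2 to compound 3 (within the scatter) both stay inside the scatter. Compound 4 `CCc1cc(C(C)=O)c(O)cc1OCCCCCC(C)(C)c1nnnn1C` differs from compound 3 in one place: 1-methyl-1H-tetrazol-5-yl in place of carboxy on a saturated chain carbon bound to three saturated chain carbons. Going by the values given here, no measured step exchanges a carboxy for a tetrazole ring. The closest comparison, cyano replaced by carboxy, gave a number 3 percentage points higher from compound 1 to compound 3 (within the scatter), and the chain change gave a number 6 percentage points lower from compound 1 to compound 2 (within the scatter), both within the scatter. The expected step is therefore a number 2 percentage points lower from compound 3 to compound 4 (within the scatter), in no firm direction. Compound 4 is estimated at 18%, within a range from 5% to 35%.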

Compound 4, a percentage reported as inhibition, at one concentration (the size of the read-out at that concentration, not a potency): 14%
Compound 4: the middle estimate sits 4 percentage points above what was measured; measured number inside the range.
By their numbers in this assay, from the lowest: compounds 2, 4, 1 and 3 (each within the scatter of the next).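

In this assay the swap of carboxy for 1-methyl-1H-tetrazol-5-yl gives a number 6 percentage points lower from compound 3 to compound 4 (within the scatter) on this saturated chain carbon, so a ring with 0 hydrogen-bond donors can sit here with no difference that stands clear of the scatter. The readings a number 3 percentage points lower from compound 1 to compound 4 (within the scatter) and a number 3 percentage points higher from compound 2 to compound 4 (within the scatter) are just as unresolved, so the carboxy, the nitrile and the tetrazole cannot be ranked at this place. Nothing measured here offers an explanation for these small differences.

Still open, from the compounds shown here alone, is whether an amine, an amide or a tetrazole with hydrogen in place of its methyl would move the number beyond the scatter. Going by these compounds, it is also open whether the tetrazole would read the same on the longer chain of compound 2.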